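Weak Inhibitors: Changing the Phenyl Group on the Triazole

This account rests on a few compounds, and the source may have more. Where it says the series, first, only, none or still open, it means among the compounds named here.

Compound 1 `CC(C)n1ncc2c(C(=O)NCc3cn(-c4cccc(Br)c4)nn3)cccc21`: 33700 nM
Compound 2 `CC(C)n1ncc2c(C(=O)NCc3cn(-c4ccc([N+](=O)[O-])cc4)nn3)cccc21`: > 40000 nM

In a functional assay on PC-3 cells (Homo sapiens) for inhibition, read by MTT assay, with a stated time of 72 h (a lower number here means a stronger inhibitor, a higher number a weaker inhibitor), compound 1 gives 33700 nM. Compound 2 reaches only a limit, not a number: the limit of > 40000 nM in this assay, at which 1 of the 2 values shown sits. Among the compounds with values here, the one measured step, an at least 1.1-fold higher number from compound 1 to compound 2 (0.07 log units; that floor lies within the scatter), therefore shows no change beyond the scatter. Compound 3 `CC(C)n1ncc2c(C(=O)NCc3cn(-c4ccccc4F)nn3)cccc21` differs from compound 2 by 2-fluorophenyl in place of 4-nitrophenyl on an aromatic nitrogen. Within the data shown here, only that single step bears on this change, and it was small, so no movement beyond the scatter is expected in this assay. Compound 3 is estimated at 35000 nM, with a range from 10000 nM to 100000 nM, which means an expected step of an at least 1.1-fold lower number from compound 2 to compound 3 (0.05 log units; that floor lies within the scatter).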

Compound 3, half-maximal inhibitory concentration: > 40000 nM
Compound 3: only a limit was reported; the forecaster's own chance of this, stated with the estimate: 45%; at least 1.1-fold (0.05 log units) between middle value and limit.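

In this assay, 2-fluorophenyl in place of 3-bromophenyl gives an at least 1.1-fold higher number from compound 1 to compound 3 (0.07 log units; that floor lies within the scatter), so a fluorine at this new ring position brings no gain that can be read. Compound 2 and compound 3 both end in limits, and the step between them cannot be read. This position now shows a second phenyl group that ends at the same limit: the limit of > 40000 nM in this assay, at which 2 of the 3 values shown sit.

From the compounds shown here alone, whether any group on this aromatic nitrogen can give a clearly stronger inhibitor remains open. A phenyl ring carrying an amine or a carboxylic acid, or a longer chain in place of the phenyl ring, could behave differently.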